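The source may report more compounds than this note shows. Statements on the series, on what has been measured and on what is new or still open speak of the compounds shown alone.

Measured so far in an ADME assay on the whole organism for pharmacokinetics, with Rattus norvegicus as the target, with a stated time of 6 h, at a dose of 10 mg/kg by the oral route; on this read-out higher numbers stand for higher exposure at the dose given and lower numbers for lower exposure:
Compound 1 `Cc1cn2c(-c3cn[nH]c3)cnc2c(Nc2cc(Cc3ccccn3)ns2)n1` gives 6880 ng.h/mL.
Compound 2 `Cc1cn2c(-c3cn[nH]c3)cnc2c(Nc2cc(Cc3cccc(F)n3)ns2)n1` gives 2970 ng.h/mL.
Compound 3 `Cc1cn2c(-c3cn[nH]c3)cnc2c(Nc2cc(Cc3cccc(CO)n3)ns2)n1` gives "not determined" (no result reported), that is, no result was reported for it.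

Going by the values given here, the only measured step, a 2.3-fold lower number from compound 1 to compound 2 (0.36 log units; beyond the scatter), concerns a change at another place on the shared core and so does not bear directly on the move to compound 4 `Cc1cn2c(-c3cn[nH]c3)cnc2c(Nc2cc(Cc3cccc(C(=O)N4CCCCC4)n3)ns2)n1`, which carries (piperidin-1-yl)carbonyl in place of hydroxymethyl on an aromatic carbon. Among the compounds with values here, with no number for compound 3 and no measured step of the same kind, neither the size nor the direction of the change in this assay can be read from the data; only the span between compound 1 and compound 2 gives a sense of scale. Compound 4 is therefore estimated at 2000 ng.h/mL, with a wide range from 300 ng.h/mL to 12000 ng.h/mL, an expectation held loosely.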

Compound 4, area under the concentration-time curve: 50 ng.h/mL
Beside the measured number, compound 4's estimate is 40-fold (1.60 log units) above it, outside the stated range (below it).
By their numbers in this assay, from the lowest: compound 4; then compound 2; then compound 1.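

In this assay, (piperidin-1-yl)carbonyl on the aromatic carbon next to the ring nitrogen brings a 140-fold lower number from compound 1 to compound 4 (2.14 log units; beyond the scatter) and a 59-fold lower number from compound 2 to compound 4 (1.77 log units; beyond the scatter) and so shows that a change at this position can move exposure far more than the fluoro change did. No measurement at hand bears on the reason for this drop.

The steps involving compound 3 cannot be read, as it has no reported result. On these data alone, whether the loss goes with the carbonyl or with the six-membered non-aromatic ring stays open, and a primary amide or a carboxylic acid on the same carbon could separate the two.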